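This account rests on a few compounds, and the source may have more. Where it says the series, first, only, none or still open, it means among the compounds named here.

Measured compounds:
Compound 1, `COc1ccc([C@@H]2CC(=O)c3c(O)cc(OCc4cn(Cc5ccccc5C#N)nn4)cc3O2)cc1O`: 14600 nM
Compound 2, `COc1ccc([C@@H]2C/C(=N\O)c3c(O)cc(OCc4cn(Cc5ccccc5F)nn4)cc3O2)cc1O`: 5710 nM
Compound 3, `C#CCOc1cc(O)c2c(c1)O[C@H](c1ccc(OC)c(O)c1)C/C2=N\O`: 19100 nM

These three compounds were tested in a functional assay on RAW264.7 cells (Mus musculus) for inhibition, read by Griess assay, with stated times of 2 h and 24 h; a lower number here means a stronger inhibitor, a higher number a weaker inhibitor. Compound 1 stands second highest of the three numbers. Its nearest neighbour is compound 3, whose number lies within the usual scatter of such measurements, so the two cannot be told apart. Compound 2 gives a clearly lower number, beyond the scatter, so it is the stronger inhibitor of that pair. Within the data shown here, each of compounds 2 and 3 differs from compound 1 in more than one place, so no single step between measured compounds can be read from these data.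

Compound 4, `CCCCn1cc(COc2cc(O)c3c(c2)O[C@H](c2ccc(OC)c(O)c2)CC3=O)nn1`, has not yet been measured. It differs from compound 1 in one place: propyl in place of 2-cyanophenyl on a saturated chain carbon bound to an aromatic nitrogen. The shared core and the ketone are kept; only the group on the saturated chain carbon bound to the aromatic nitrogen changes. Among the measured compounds shown here, no measured pair isolates this change, so the size of the step cannot be anchored. The expectation is a step in this assay from compound 1 to compound 4 of a 1.5-fold higher number from compound 1 to compound 4 (0.18 log units; within the scatter), a small loss that may not reach beyond the scatter. For compound 4 the estimated value in this assay is 22000 nM, with a range from 9000 nM to 55000 nM.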

Compound 4, half-maximal inhibitory concentration: 13900 nM
The estimate for compound 4 lay 1.6-fold (0.20 log units) above the measured number; the measured number falls inside the stated range.
By their numbers in this assay, from the lowest: compound 2; then compounds 4, 1 and 3 (each within the scatter of the next).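

In this assay, putting propyl in place of 2-cyanophenyl on a saturated chain carbon bound to an aromatic nitrogen gives a 1.1-fold lower number from compound 1 to compound 4 (0.02 log units; within the scatter), so the two compounds cannot be told apart. Among these compounds, this is the first comparison here that isolates a single change, and it shows that, with the ketone and the shared core kept, the aromatic ring and the nitrile can both go without a detectable shift in the number. Nothing measured here explains why the number holds steady at this position.

Still open, from the compounds shown here alone, is whether the same holds for other groups at this position, such as an amine, a carboxylic acid or a longer chain. Going by these compounds, it is also open whether this swap would read the same with the group that compound 2 carries in place of the ketone.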